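Ester aryl swap: fluoro to methyl, metabolic stability

The source may report more compounds than this note shows. Statements on the series, on what has been measured and on what is new or still open speak of the compounds shown alone.

Compound 3 `O=C(OC1CCC(CN2CCN(c3cc(=O)c4cc(C(F)(F)F)cc([N+](=O)[O-])c4s3)CC2)CC1)c1ccc(F)cc1` gives 0.0983 h in an ADME assay on cells (Hepatocyte, Homo sapiens) for metabolic stability; a higher number here means that the compound lasts longer, a lower number that the compound disappears faster. Of the two numbers shown in this assay, that of compound 3 sits alongside compound 1 `O=C(OC1CCC(CN2CCN(c3cc(=O)c4cc(C(F)(F)F)cc([N+](=O)[O-])c4s3)CC2)CC1)c1ccco1`, which gives 0.075 h in this assay, and the gap a 1.3-fold higher number from compound 1 to compound 3 (0.12 log units; within the scatter) is within the scatter. Compound 2 `CC(=O)NC1CCC(CN2CCN(c3cc(=O)c4cc(C(F)(F)F)cc([N+](=O)[O-])c4s3)CC2)CC1` gives only a limit of this assay, > 1.55 h, not a number (the limit of > 1.55 h in this assay, at which 1 of the 3 values shown sits). Going by the values given here, the steps of an at least 20-fold higher number from compound 1 to compound 2 (1.31 log units; beyond the scatter) and an at least 15-fold lower number from compound 2 to compound 3 (1.19 log units; beyond the scatter) turn on acetamido replacing the ester and are large; the one step that alters only the aryl of the ester, a 1.3-fold higher number from compound 1 to compound 3 (0.12 log units; within the scatter), is within the scatter.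

Compound 4 `Cc1ccc(C(=O)OC2CCC(CN3CCN(c4cc(=O)c5cc(C(F)(F)F)cc([N+](=O)[O-])c5s4)CC3)CC2)cc1` differs from compound 3 by methyl in place of fluoro on an aromatic carbon. Among the compounds with values here, the only measured step that bears on this change is a 1.3-fold higher number from compound 1 to compound 3 (0.12 log units; within the scatter), which stayed within the scatter, so no step beyond the scatter is expected in this assay, in either direction. Compound 4 is therefore expected to give 0.1 h in this assay, with a range from 0.04 h to 0.25 h. The step of a 1.0-fold higher number from compound 3 to compound 4 (0.01 log units; within the scatter) is expected to remain within the scatter.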

Compound 4, half-life: 0.148 h
Compound 4: the middle estimate sits 1.5-fold (0.17 log units) below what was measured, within the range that was stated.
By their numbers in this assay, from the lowest: compounds 1, 3 and 4 (each within the scatter of the next). At a limit, above all of these: compound 2.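

On the aromatic carbon para to a large group, methyl in place of fluoro stays within the scatter in this assay: a 1.5-fold higher number from compound 3 to compound 4 (0.18 log units; within the scatter). Furan-2-yl and 4-methylphenyl on the carbonyl carbon are likewise not separated, with a 2.0-fold higher number from compound 1 to compound 4 (0.30 log units; within the scatter), while the large step against the acetamido compound now holds for a third ester, with an at least 10-fold lower number from compound 2 to compound 4 (1.02 log units; beyond the scatter). Compound 2 remains a limit of the assay, not a number: the limit of > 1.55 h in this assay, at which 1 of the 4 values shown sits.

Open, as far as these compounds go, is whether an amine or a carboxylic acid on that aromatic carbon would also stay within the scatter in this assay. Also open, from the compounds shown here alone, is how a longer chain in place of the acetyl part of the acetamido group of compound 2 would read there.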